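The compounds below may be only part of what the source reports. "The series", "measured", "known", "first", "only" and "open" are said of these compounds alone.

Series notes. Compound 1 `CCN(c1ccc(C#N)c(Cl)c1)c1cc(-c2cncnc2)ccc1C` is one of two measured compounds in a functional assay on VCaP cells (Homo sapiens) for antiproliferative activity, read by CCK-8 assay, with a stated time of 6 days (on this read-out higher numbers stand for weaker inhibition and lower numbers for stronger inhibition), where compound 1 gives 3920 nM. Compound 2 `N#Cc1ccc(N2CCc3cc(-c4cccnc4)ccc3C2)cc1C(F)(F)F` gives 2530 nM in this assay, and the two numbers lie within the scatter of each other, so compound 1 sits alongside compound 2 with no separation between them. Compound 3 `CCN(c1ccc(C#N)c(Cl)c1)c1cc(-c2ccoc2)ccc1C` is not yet measured; it differs from compound 1 by furan-3-yl in place of pyrimidin-5-yl on an aromatic carbon. Within the data shown here, no measured pair shows this change, so its effect in this assay is unknown; a step of modest size in either direction, or none beyond the scatter, is expected, as a 1.1-fold higher number from compound 1 to compound 3 (0.06 log units; within the scatter). Compound 3 is therefore estimated at 4500 nM, within 1500 nM to 14000 nM.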

Compound 3, half-maximal inhibitory concentration: 4010 nM
Beside the measured number, compound 3's estimate is 1.1-fold (0.05 log units) above it; measured number inside the range.
By their numbers in this assay, from the lowest: compounds 2, 1 and 3 (each within the scatter of the next).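

In this assay, among these compounds, furan-3-yl in place of pyrimidin-5-yl, on the aromatic carbon para to a methyl group, gives a 1.0-fold higher number from compound 1 to compound 3 (0.01 log units; within the scatter) and is the first reading at this position. A six-membered aromatic ring with 2 hetero atoms and a five-membered one with 1 hetero atom are not separated here. Nothing measured in this set accounts for this result.

Still open, on these data alone, is whether an amine, a carboxylic acid or a morpholine ring at this carbon would give a step beyond the scatter. Compound 2 differs from compound 1 in more than one place, so it does not inform this position.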